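From a Nitrooxy Ring to a Chlorinated Ring

The source may report more compounds than this note shows. Statements on the series, on what has been measured and on what is new or still open speak of the compounds shown alone.

Of the compounds shown here, three built on one shared core have been tested in a functional assay on U-87MG ATCC cells (Homo sapiens) for cytotoxicity, read by MTT assay, with a stated time of 72 h; on this read-out higher numbers stand for weaker inhibition and lower numbers for stronger inhibition. Compound 1 `CN(C)CCn1cnnc1-c1cc(Oc2ccc(NC(=O)N/N=C/c3ccc(Cl)cc3Cl)cc2F)ccn1` gives 2330 nM. Compound 2 `COc1ccc(/C=N/NC(=O)Nc2ccc(Oc3ccnc(-c4nncn4CCN(C)C)c3)c(F)c2)c(OC)c1` gives 12600 nM, and compound 3 `CN(C)CCn1cnnc1-c1cc(Oc2ccc(NC(=O)N/N=C/c3ccccc3O[N+](=O)[O-])cc2F)ccn1` gives 7150 nM. Among these three numbers compound 3 stands second highest; the measured difference between compound 2 and compound 3 is a 1.8-fold lower number from compound 2 to compound 3 (0.25 log units; within the scatter), so no order can be claimed between them. The step to compound 1 is larger: a 3.1-fold higher number from compound 1 to compound 3 (0.49 log units; beyond the scatter).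

Compound 4 `CN(C)CCn1cnnc1-c1cc(Oc2ccc(NC(=O)N/N=C/c3ccc(Cl)cc3)cc2F)ccn1` has not yet been measured. It differs from compound 3 in a single place: 4-chlorophenyl in place of 2-(nitrooxy)phenyl on a carbon with a double bond to nitrogen.

Within the data shown here, the step that bears on this change is the one from compound 1 to compound 3, where a 2,4-dichlorophenyl was exchanged for the 2-(nitrooxy)phenyl and the number rose beyond the scatter. The 4-chlorophenyl entering in compound 4 is, like the group in compound 1, an aromatic ring carrying chlorine, but with one chlorine where compound 1 has two. Reversing the nitrooxy-to-chlorine exchange is therefore expected to bring the number back down, as the expected step of a 2.0-fold lower number from compound 3 to compound 4 (0.31 log units; beyond the scatter) describes, though perhaps not all the way to compound 1. Compound 4 is estimated at 3500 nM, within a range from 1500 nM to 8000 nM.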

Compound 4, half-maximal inhibitory concentration: 1370 nM
The estimate for compound 4 lay 2.6-fold (0.41 log units) above the measured number, outside the stated range (below it).
By their numbers in this assay, from the lowest: compounds 4 and 1 (each within the scatter of the next); then compounds 3 and 2 (each within the scatter of the next).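

In this assay, a single chlorine on the ring is enough for the lower numbers at this place, on a carbon with a double bond to nitrogen: swapping 2-(nitrooxy)phenyl for 4-chlorophenyl gives a 5.2-fold lower number from compound 3 to compound 4 (0.72 log units; beyond the scatter), and swapping 2,4-dimethoxyphenyl for 4-chlorophenyl gives a 9.2-fold lower number from compound 2 to compound 4 (0.96 log units; beyond the scatter). The earlier compounds shown here could not separate the effect of having a chlorinated ring from that of having two chlorines, but hydrogen in place of chloro on an aromatic carbon gives a 1.7-fold lower number from compound 1 to compound 4 (0.23 log units; within the scatter), which is within the scatter, so the second chlorine of compound 1 brings no readable difference and compound 1 and compound 4 cannot be ranked. Among these four compounds, the two rings carrying chlorine give the lower numbers, but no measurement at hand says why these rings differ in this way.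

On these data alone, it remains open whether chlorine itself matters at this place, as the numbers for a plain phenyl, a 4-fluorophenyl or a 4-bromophenyl ring on the same shared core would show. As far as these compounds go, it is also open whether a ring with chlorine only at its 2-position would match compound 4.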